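The compounds below may be only part of what the source reports. "The series", "measured", "known", "first", "only" and "open" are said of these compounds alone.

Values in a functional assay with Oryctolagus cuniculus as the target; on this read-out lower numbers stand for stronger inhibition and higher numbers for weaker inhibition:
- Compound 1 `CNC(=O)NCc1nc(-c2ccc(OC)cc2)c(-c2ccc(OC)cc2)s1`: 22 nM.
- Compound 2 `COc1ccc(-c2nc(C(N)=O)sc2-c2ccc(OC)cc2)cc1`: > 1000 nM, a limit of the assay and not a number.
- Compound 3 `CCN(CC)C(=O)c1nc(-c2ccc(OC)cc2)c(-c2ccc(OC)cc2)s1`: < 10 nM, also a limit and not a number.

Compound 3 is the strongest of the three. The steps leading to it are an at least 2.2-fold lower number from compound 1 to compound 3 (0.34 log units; beyond the scatter) and an at least 100-fold lower number from compound 2 to compound 3 (2.00 log units; beyond the scatter).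

Compound 4 `CCOC(=O)/C=C/c1nc(-c2ccc(OC)cc2)c(-c2ccc(OC)cc2)s1` has not yet been measured. In it, 2-(ethoxycarbonyl)ethenyl replaces diethylcarbamoyl on an aromatic carbon (2-(ethoxycarbonyl)ethenyl in place of diethylcarbamoyl on an aromatic carbon).

Going by the values given here, all the measured steps change the group at this same place, and the remaining one is an at least 45-fold higher number from compound 1 to compound 2 (1.65 log units; beyond the scatter). Their sizes run from at least modest to large, so the choice of group here clearly matters in this assay. None of them makes this particular swap, however, so they give only a loose guide.

A moderate move toward weaker inhibition is expected, with the estimated step being an at least 4.0-fold higher number from compound 3 to compound 4 (0.60 log units; beyond the scatter). The estimate for compound 4 is 40 nM, with an expected range of 6 nM to 300 nM.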

Compound 4, half-maximal inhibitory concentration: 20 nM
Estimate against measurement, compound 4: 2.0-fold (0.30 log units) above; the measured number falls inside the stated range.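

Nitrogen is not needed in the group at this position: every group here that gave strong inhibition so far contained nitrogen, yet 2-(ethoxycarbonyl)ethenyl contains none and still performs on a par with ((methylcarbamoyl)amino)methyl in this assay, with a 1.1-fold lower number from compound 1 to compound 4 (0.04 log units; within the scatter). The new group also far outdoes the small carbamoyl group, with an at least 50-fold lower number from compound 2 to compound 4 (1.69 log units; beyond the scatter), so compound 2 is the one that stands apart among the four. Against diethylcarbamoyl the result is an at least 2.0-fold higher number from compound 3 to compound 4 (0.30 log units; that floor lies within the scatter), and the true size of this step stays unknown because compound 3 is reported only as a limit: the limit of < 10 nM in this assay, at which 1 of the 4 values shown sits.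

The compounds shown leave open whether the ester or the double bond of 2-(ethoxycarbonyl)ethenyl matters more. A carboxylic acid in place of the ethyl ester, or a saturated chain in place of the ethenyl link, would help separate the two.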